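The source may hold more compounds than are shown below. What is called first, only, known or untested is meant among the compounds shown, and "the series" means these compounds.

Four compounds built on one shared core are under consideration. In a functional assay on the whole organism (strain NMRI) with Mus musculus as the target, with a stated time of 5 min (on this read-out higher numbers stand for an effect only at larger amounts of compound and lower numbers for an effect already at smaller amounts), compound 1 `CCC1(CCCCN2CCN(c3ccc(F)c(Cl)c3)CC2)C(=O)Nc2ccccc21` gives "not determined" (no result reported). Compound 2 `CCC1(CCCCN2CCN(c3cccc(Cl)c3)CC2)C(=O)Nc2cc(F)ccc21` likewise gives "not determined" (no result reported) in this assay. Compound 3 `CCC1(CCCCN2CCN(c3ccc(Cl)cc3)CC2)C(=O)Nc2ccccc21` reaches only a limit of the assay in this assay, namely > 10 mg/kg. That limit is where compound 3 stands, the single bounded result among the three entries, as the limit of > 10 mg/kg in this assay, at which 1 of the 3 values shown sits, records. Compound 4 `CCC1(CCCCN2CCN(c3ccc(Cl)cc3)CC2)C(=O)Nc2cc(F)ccc21` differs from compound 3 by fluoro in place of hydrogen on an aromatic carbon. Going by the values given here, no step between measured compounds is available, so the size of this change in this assay is open; a step no larger than the usual scatter, in either direction, is expected. Compound 4 is therefore estimated at 15 mg/kg, within 5 mg/kg to 40 mg/kg. The expected step that the limit leaves unreadable from compound 3 to compound 4 is small.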

Compound 4, minimum effective dose: > 10 mg/kg
Compound 4: a limit, no number (the forecaster's own chance of this, stated with the estimate: 70%); the middle value lies beyond the limit too.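

Going by these compounds alone, compound 3 and compound 4 both give only a limit of the assay, and no step between them can be read in this assay. The compounds shown leave open whether fluoro in place of hydrogen on an aromatic carbon shifts the minimum effective dose at all.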